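Extending a Methyl to an Ethyl on the Shared Core

This account rests on a few compounds, and the source may have more. Where it says the series, first, only, none or still open, it means among the compounds named here.

Compound 1 `Nc1nc(N)c2nc(CCc3ccc(C(=O)NC(CCC(=O)O)C(=O)O)c4ccccc34)cnc2n1` and compound 2 `Cc1c(CCc2ccc(C(=O)NC(CCC(=O)O)C(=O)O)c3ccccc23)cnc2nc(N)nc(N)c12` have both been tested in a functional assay on L1210 cells (Mus musculus) for inhibition; on this read-out higher numbers stand for weaker inhibition and lower numbers for stronger inhibition. In this assay compound 1 gives 1.5 nM, and compound 2 gives 8.8 nM, the higher of the two numbers shown, so compound 2 is the weaker inhibitor of the pair. Compound 3 `CCc1c(CCc2ccc(C(=O)NC(CCC(=O)O)C(=O)O)c3ccccc23)cnc2nc(N)nc(N)c12` has not yet been measured. It differs from compound 2 in one place: methyl in place of hydrogen on a saturated chain carbon bound to an aromatic carbon, so that the methyl of compound 2 becomes an ethyl. For the measured compounds named here, no step between two measured compounds covers this change, so any expectation rests on the two values alone. The numbers show that compound 1, which carries no group at this position, is the stronger of the two measured inhibitors. Relative to compound 2, compound 3 is expected to show a step of a 1.7-fold higher number from compound 2 to compound 3 (0.23 log units; within the scatter), toward about the same or a somewhat weaker inhibition. Compound 3 is therefore estimated at 15 nM, with a range from 5 nM to 50 nM.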

Compound 3, half-maximal inhibitory concentration: 9 nM
Beside the measured number, compound 3's estimate is 1.7-fold (0.22 log units) above it; the measured number falls inside the stated range.
By their numbers in this assay, from the lowest: compound 1; then compounds 2 and 3 (each within the scatter of the next).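

Extending the methyl of compound 2 to the ethyl of compound 3 gives, in this assay, a 1.0-fold higher number from compound 2 to compound 3 (0.01 log units; within the scatter), so the two compounds cannot be told apart on this read-out. For the compounds shown here, this is the first step that can be read at this saturated chain carbon bound to an aromatic carbon, and it shows that the shared core accepts one added carbon here with no change beyond the scatter. No supporting data accompany this result, so the reason for it stays unknown.

What the compounds shown leave open is whether this flat step holds for a propyl or isopropyl chain, or for a group such as an amine or a carboxylic acid. They also leave open how a plain hydrogen at this position would compare on the core of compound 2.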